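Same Methyl Step, Same Silent Read-out Expected

A few compounds are considered here, and "the series" means these few. Any claim that something is new, unique, unknown or untested is made for them only; others in the source may bear on it.

Three compounds that share one core and differ only on the aromatic ring have been tested. Compound 1 `COc1ccc(/C=C/C2(C)C=CC(=O)O2)c(OC)c1OC` carries three methoxy groups on that ring, compound 2 `COc1c(O)ccc(/C=C/C2(C)C=CC(=O)O2)c1OC` has a hydroxy in place of one of them, and compound 3 `CC1(/C=C/c2ccc(O)cc2)C=CC(=O)O1` carries a single hydroxy. The assay is a functional assay on K562 cells (Homo sapiens) for inhibition, read by sulforhodamine B assay, with a stated time of 48 h; a higher number here means a weaker inhibitor of growth, a lower number a stronger inhibitor of growth. In this assay compound 1 gives only a limit, > 1000000 nM. Compound 2 likewise gives a limit, > 1000000 nM. Compound 3 also gives a limit, > 1000000 nM. Every value here is a limit of the assay, (the limit of > 1000000 nM in this assay, at which 3 of the 3 values shown sit), so no number is known for any of the three.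

The change from compound 2 to compound 1 is methyl in place of hydrogen on an oxygen on an aromatic ring. The step it made is a step that the two limits leave unreadable from compound 2 to compound 1. How the core of compound 3 differs from that of compound 2 is not broken down here.

Compound 4 `COc1ccc(/C=C/C2(C)C=CC(=O)O2)cc1` has not yet been measured. It arises from compound 3 by methyl in place of hydrogen on an oxygen on an aromatic ring, the same change as between compound 2 and compound 1. Because compound 3 gives only the limit > 1000000 nM, and because the matching step elsewhere was a step that the two limits leave unreadable from compound 2 to compound 1, the expected step is a number no higher from compound 3 to compound 4 (the limit leaves the size open). Compound 4 is therefore estimated to sit at 1000000 nM, most likely between 300000 nM and 3000000 nM.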

Compound 4, concentration for total growth inhibition: > 1000000 nM
Compound 4 gave a limit, no number; the forecaster's own chance of this, stated with the estimate: 85%; the middle value sits exactly at the limit.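

No size can be read for the hydroxy to methoxy step between compound 3 and compound 4: each gives only a limit, not a number. All four compounds share one limit: the limit of > 1000000 nM in this assay, at which 4 of the 4 values shown sit.

The compounds shown leave open whether methyl in place of hydrogen on that oxygen changes growth inhibition at all, and what change to the shared core would give a measurable number.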